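The compounds below may be only part of what the source reports. "The series", "measured", "known", "first", "only" and "open" are said of these compounds alone.

In a functional assay on HT-29 cells (Homo sapiens) for cytotoxicity, read by MTT assay, with a stated time of 24 h, tested at 1.6 ug/mL (on this read-out higher numbers stand for a stronger effect at the one concentration tested and lower numbers for a weaker effect), compound 2 `Cn1c(-c2ccc(NC(=O)CN3CCN(c4ccccc4)CC3)cc2)nc(-c2ccccc2)c1-c1ccccc1` gives 26% and compound 1 `CN1CCN(CC(=O)Nc2ccc(-c3nc(-c4ccccc4)c(-c4ccccc4)n3C)cc2)CC1` gives 27.4%; these two numbers, the only ones measured so far, lie within the usual scatter of each other. Going by the values given here, compound 3 `Cn1c(-c2ccc(NC(=O)CN3CCN(Cc4ccccc4)CC3)cc2)nc(-c2ccccc2)c1-c1ccccc1` differs from compound 2 in one place (benzyl in place of phenyl on an amine nitrogen in a ring), on the same ring nitrogen that was changed in the one measured step, a number 1.4 percentage points lower from compound 1 to compound 2 (within the scatter), which stayed within the scatter. No change beyond the scatter is therefore expected in this assay for compound 3, an expected step of no change at the digits printed from compound 2 to compound 3 (within the scatter) from compound 2. Compound 3 is estimated at 26%, in the range 14% to 38%.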

Compound 3, a percentage reported as activity, at one concentration (the size of the read-out at that concentration, not a potency): 26%
For compound 3 middle estimate and measured number coincide at the digits printed, within the range that was stated.
By their numbers in this assay, from the lowest: compounds 2, 3 and 1 (each within the scatter of the next).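

In this assay, benzyl in place of phenyl on this amine nitrogen in a ring gives no change at the digits printed from compound 2 to compound 3 (within the scatter), and the comparison with the methyl group gives a number 1.4 percentage points lower from compound 1 to compound 3 (within the scatter). Methyl, phenyl and benzyl thus now all read alike here, so adding a saturated carbon to the phenyl group changes nothing beyond the scatter. No measurement is available to explain this result. As far as these compounds go, whether a free amine, a carboxylic acid or a longer chain on this nitrogen would move the number beyond the scatter remains open.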